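A Longer Amide Tail for Compound 1

The source may hold more compounds than are shown below. What is called first, only, known or untested is meant among the compounds shown, and "the series" means these compounds.

Compound 1 `COc1cc2ncnc(N3CCc4ccccc43)c2cc1NC(=O)C=C(C)C` was assessed in a functional assay on A549 cells (Homo sapiens) for antiproliferative activity, read by MTT assay, with a stated time of 72 h (a higher number here means a weaker inhibitor, a lower number a stronger inhibitor), where compound 1 gives 6270 nM. Among the three measured compounds this is the second highest number. Compound 2 `CC(C)=CC(=O)Nc1cc2c(N3CCc4ccccc43)ncnc2cc1O[C@@H]1CCOC1`, which gives 3670 nM, is the nearest neighbour: a 1.7-fold lower number from compound 1 to compound 2 (0.23 log units; within the scatter). Compound 3 `CC/C=C/C(=O)Nc1cc2c(N3CCCc4ccccc43)ncnc2cc1O[C@@H]1CCOC1`, which gives 14100 nM, is the furthest, beyond the scatter. Compound 4 `COc1cc2ncnc(N3CCc4ccccc43)c2cc1NC(=O)/C=C/CN1CCN(C)CC1` differs from compound 1 in one place: 3-(4-methylpiperazin-1-yl)prop-1-en-1-yl in place of 2-methylprop-1-en-1-yl on a carbonyl carbon. For the measured compounds named here, the only measured single-change step, the one from compound 1 to compound 2, concerns the oxygen on the aromatic ring and not the carbonyl carbon, so no measured step bears directly on this change. Compound 2 and compound 3 differ from each other in more than one place, so their two values give no single-change comparison either. With nothing to anchor the direction, the author expects a modest step, if any, from compound 1 to compound 4, a 1.8-fold lower number from compound 1 to compound 4 (0.25 log units; within the scatter). Compound 4 is therefore estimated at 3500 nM, with a range from 900 nM to 13000 nM.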

Compound 4, half-maximal inhibitory concentration: 5360 nM
Compound 4: the middle estimate sits 1.5-fold (0.19 log units) below what was measured; low and high end bracket the measured number.
By their numbers in this assay, from the lowest: compounds 2, 4 and 1 (each within the scatter of the next); then compound 3.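

In this assay, for the compounds shown here, the replacement on the carbonyl carbon gives a 1.2-fold lower number from compound 1 to compound 4 (0.07 log units; within the scatter), and this is the only measured change at this place. The entering 3-(4-methylpiperazin-1-yl)prop-1-en-1-yl brings a six-membered non-aromatic ring with 2 hetero atoms and 2 hydrogen-bond acceptors that 2-methylprop-1-en-1-yl lacks, yet the step stays within the scatter, so this place accepts the larger group without a readable change in the number. Nothing available here offers an explanation for this result.

As far as these compounds go, whether a simple dimethylamino group in place of the 4-methylpiperazin-1-yl ring, or a longer chain carrying that ring, would give a similar number remains open. Also open, from the compounds shown here alone, is whether the same replacement would give a similar step with oxolan-3-yl in place of methyl on the oxygen.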